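The source may report more compounds than this note shows. Statements on the series, on what has been measured and on what is new or still open speak of the compounds shown alone.

Working notes on a short series of agonists read in a functional assay on cells for agonist activity at Free fatty acid receptor 1 (Homo sapiens), read by calcium flux; on this read-out higher numbers stand for an effect only at larger amounts of compound and lower numbers for an effect already at smaller amounts. Compound 1 `Cc1cccc(C)c1-c1cccc(OCc2cn(CCC(=O)O)nn2)c1` gives 14700 nM in this assay. Compound 2 `O=C(O)CCc1ccc(OCc2cccc(-c3ccccc3C(F)(F)F)c2)s1` gives 2710 nM. Compound 3 `Cc1cccc(C)c1-c1cccc(COc2ccc(C(CC(=O)O)C3CC3)s2)c1` gives 3920 nM, which is the second highest of the three numbers; its nearest neighbour is compound 2, within the usual scatter, and its furthest is compound 1, whose number is higher by more than the scatter. Going by the values given here, the three measured compounds differ from one another in several places at once, so no single step between them can be read from these numbers.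

Compound 4 `CCOC(CC(=O)O)c1ccc(OCc2cccc(-c3c(C)cccc3C)c2)s1` has not yet been measured in this assay. It differs from compound 3 in one place: ethoxy in place of cyclopropyl on a saturated chain carbon bound to an aromatic carbon and a saturated chain carbon. The rest of compound 3 is kept. No step of this kind between measured compounds is known in this set, so the size of the effect cannot be read from anything shown. The expectation for compound 4 is a step no larger than the scatter, in either direction, and the estimated step is a 1.0-fold higher number from compound 3 to compound 4 (0.01 log units; within the scatter). The estimate for compound 4 in this assay is 4000 nM, with a range from 1500 nM to 12000 nM.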

Compound 4, half-maximal effective concentration: 57 nM
For compound 4 the middle estimate is 70-fold (1.85 log units) above the measured one, and the stated range ends above it.
By their numbers in this assay, from the lowest: compound 4; then compounds 2 and 3 (each within the scatter of the next); then compound 1.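

In this assay the place on a saturated chain carbon bound to an aromatic carbon and a saturated chain carbon proves sensitive to what it carries: ethoxy in place of cyclopropyl gives a 69-fold lower number from compound 3 to compound 4 (1.84 log units; beyond the scatter) and so lies beyond the scatter, although the heavy-atom count stays the same. The earlier compounds shown here differ from one another in several places at once. Going by these compounds alone, this is the first single change that can be read, and it shows that this one place alone can shift the number strongly while the rest of compound 3 is kept. No independent measurement is available to explain the size of this step.

The change removes a three-membered carbon ring and adds an oxygen with one hydrogen-bond acceptor in the same step, so the compounds shown do not separate the loss of the ring from the entry of the oxygen. An open propyl chain would address the first part and a methoxy or propoxy group would show how the number follows the length of the chain on the oxygen, while a hydroxyl or an amine at this place remains an open comparison.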